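Sulfur for Nitrogen on the Quinone Ring of Compound 1

The source may hold more compounds than are shown below. What is called first, only, known or untested is meant among the compounds shown, and "the series" means these compounds.

Compound 1 `COc1cc(C)cc2c1C(=O)C=C(c1c(C)cc3c(c1OC)C(=O)C(NCCO)=CC3=O)C2=O` and compound 2 `CCOc1cc(C)cc2c1C(=O)C=C(c1c(C)cc3c(c1OCC)C(=O)C(NCCO)=CC3=O)C2=O` share a core and differ only in their alkoxy groups. For the measured compounds named here, in a functional assay on Ehrlich cells (Mus musculus) for cytotoxicity, read by MTT assay, with a stated time of 24 h (a higher number here means a weaker inhibitor, a lower number a stronger inhibitor), compound 1 gives 1070 nM, the higher of the two numbers known, while compound 2 gives 30 nM, a gap described as well beyond the scatter. Going by the values given here, since the two compounds differ in more than one place, no single step can be drawn between them.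

Compound 3 `COc1cc(C)cc2c1C(=O)C=C(c1c(C)cc3c(c1OC)C(=O)C(SCCO)=CC3=O)C2=O` is not yet measured. It keeps the methoxy groups of compound 1 and changes only the side chain on the quinone ring: (2-hydroxyethyl)sulfanyl in place of (2-hydroxyethyl)amino on a double-bonded ring carbon. There is no precedent among the measured compounds for exchanging the nitrogen link for a sulfur link, so the direction of the step rests on the change itself rather than on any shown pair. He expects a step from compound 1 to compound 3 of a 1.8-fold lower number from compound 1 to compound 3 (0.25 log units; within the scatter), modest in size and uncertain in direction. For compound 3 his estimate in this assay is 600 nM, within a range of 150 nM to 3000 nM.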

Compound 3, half-maximal inhibitory concentration: 260 nM
Compound 3: the middle estimate sits 2.3-fold (0.36 log units) above what was measured, within the range that was stated.
By their numbers in this assay, from the lowest: compound 2; then compound 3; then compound 1.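

The exchange of (2-hydroxyethyl)amino for (2-hydroxyethyl)sulfanyl on a double-bonded ring carbon supplies the only single-place comparison among these compounds, and in this assay it amounts to a 4.1-fold lower number from compound 1 to compound 3 (0.61 log units; beyond the scatter) for this change. It shows that this position responds to the linking atom alone: with the methoxy groups and the two-carbon hydroxyethyl chain held as they are, replacing nitrogen with sulfur moves the number beyond the scatter, although the step is modest. The entering group has 1 hydrogen-bond donor where the leaving group has 2, at 4 heavy atoms each, but nothing measured here ties the step to that difference or to any other cause.

The compounds shown leave open whether the same exchange would carry over to compound 2, with its ethoxy groups in place of methoxy. They also leave open how an oxygen link, as in (2-hydroxyethoxy), a longer chain on the sulfur, such as (3-hydroxypropyl)sulfanyl, or a carboxylic acid at the end of the chain would compare with compound 3.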